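The compounds below may be only part of what the source reports. "The series", "measured", "known", "first", "only" and "open" are said of these compounds alone.

Measured so far:
Compound 1 `O=c1ccc(-c2ccc3cn[nH]c3c2)cn1Cc1ccccc1C(F)(F)F` gives 133 nM in an assay for inhibition of MAP kinase-interacting serine/threonine-protein kinase 1 (Homo sapiens), read by luminescence and ADP-Glo, with a stated time of 2 h; a higher number here means a weaker inhibitor, a lower number a stronger inhibitor.
Compound 2 `NC(=O)c1ccccc1Cn1cc(-c2ccc3cn[nH]c3c2)ccc1=O` gives 878 nM.
Compound 3 `NC(=O)c1ccc(Cn2cc(-c3ccc4cn[nH]c4c3)ccc2=O)cc1` gives only a limit of the assay, > 2000 nM.

Compounds 1 and 2 share a core and differ in one place: trifluoromethyl in place of carbamoyl on an aromatic carbon. That change brought a 6.6-fold lower number from compound 2 to compound 1 (0.82 log units; beyond the scatter). Compound 3 is built from the same atoms as compound 2, joined differently; the difference between the two cores is not broken down here. Compound 4 `O=c1ccc(-c2ccc3cn[nH]c3c2)cn1Cc1ccc(C(F)(F)F)cc1` has not yet been measured. It differs from compound 3 by trifluoromethyl in place of carbamoyl on an aromatic carbon. Here the entering group sits para to a large group, whereas in compound 1 it sits ortho to a large group, so this is the same kind of change, not the same.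

Because the limit of > 2000 nM in this assay, at which 1 of the 3 values shown sits, holds for compound 3, the starting point of the new step is itself uncertain. Resting on a 6.6-fold lower number from compound 2 to compound 1 (0.82 log units; beyond the scatter), the step expected for compound 4 is an at least 2.5-fold lower number from compound 3 to compound 4 (0.39 log units; beyond the scatter). Compound 4 is therefore estimated to give about 800 nM in this assay, most likely between 250 nM and 3000 nM.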

Compound 4, half-maximal inhibitory concentration: 1170 nM
For compound 4 the middle estimate is 1.5-fold (0.17 log units) below the measured one; measured number inside the range.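

In this assay, putting trifluoromethyl in place of carbamoyl on the second core gave an at least 1.7-fold lower number from compound 3 to compound 4 (0.23 log units; that floor lies within the scatter). This agrees in direction with the earlier step, but its floor does not by itself establish a step beyond the scatter, and the comparison shows neither that the change carries over at the same size nor that its size depends on the core: the same change on two cores in this assay, a 6.6-fold lower number (0.82 log units; beyond the scatter) from compound 2 to compound 1 and an at least 1.7-fold lower number (0.23 log units; that floor lies within the scatter) from compound 3 to compound 4; the limit leaves it open whether they differ. The new step is bounded on one side only, since compound 3 stands at a limit of the assay and not at a number: the limit of > 2000 nM in this assay, at which 1 of the 4 values shown sits.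

The compounds shown leave open how other groups on that aromatic carbon, such as a nitrile, an amine or a carboxylic acid, would read on either core. They also leave open whether the trifluoromethyl-for-carbamoyl change would move the number in the same direction on any further core.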